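The source may hold more compounds than are shown below. What is called first, only, known or untested is meant among the compounds shown, and "the series" means these compounds.

Compound 1, `NS(=O)(=O)c1ccc(-c2nc(C(c3ccc(F)cc3)c3ccc(F)cc3)sc2CC(=O)O)cc1`, in an in vitro functional assay on HEK285-7 cells for antagonist activity at prostaglandin D2 receptor 2 (Homo sapiens), read by BRET and beta-arrestin recruitment (a lower number here means a stronger inhibitor, a higher number a weaker inhibitor), gives > 100000 nM, which is a limit of the assay rather than a number.
Compound 2, `NS(=O)(=O)c1cccc(-c2nc(C(c3ccc(F)cc3)c3ccc(F)cc3)sc2CC(=O)O)c1`, in this assay gives 710 nM.

Within the data shown here, compound 2 holds the only number in this assay; the other value is a limit (the limit of > 100000 nM in this assay, at which 1 of the 2 values shown sits). The step of an at least 140-fold lower number from compound 1 to compound 2 (2.14 log units; beyond the scatter) shows how strongly the outcome depends on the aryl group on the shared core. Compound 3, `O=C(O)Cc1sc(C(c2ccc(F)cc2)c2ccc(F)cc2)nc1-c1ccncc1`, differs from compound 2 by pyridin-4-yl in place of 3-sulfamoylphenyl on an aromatic carbon. Among the measured compounds shown here, no measured step covers this exchange; the sole step, an at least 140-fold lower number from compound 1 to compound 2 (2.14 log units; beyond the scatter), only shows that the sulfamoylphenyl group matters. Its removal is expected to weaken inhibition, giving a 14-fold higher number from compound 2 to compound 3 (1.15 log units; beyond the scatter). Compound 3 is therefore estimated at 10000 nM, with a range from 1500 nM to 100000 nM.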

Compound 3, half-maximal inhibitory concentration: 40 nM
For compound 3 the middle estimate is 250-fold (2.40 log units) above the measured one, outside the stated range (below it).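

In this assay this position does not need a sulfamoylphenyl group for inhibition: pyridin-4-yl, the smaller group with no hydrogen-bond donor, brings an 18-fold lower number from compound 2 to compound 3 (1.25 log units; beyond the scatter). Set against 4-sulfamoylphenyl, the same group brings an at least 2500-fold lower number from compound 1 to compound 3 (3.39 log units; beyond the scatter), a step that rests on a limit of the assay: the limit of > 100000 nM in this assay, at which 1 of the 3 values shown sits. The compounds shown leave open whether the ring nitrogen of pyridin-4-yl matters, since plain phenyl, pyridin-3-yl and pyridin-2-yl do not appear among them.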